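The compounds below may be only part of what the source reports. "The series", "measured", "known", "first", "only" and "open" are said of these compounds alone.

The measured compounds:
compound 1, `CN1CCC/C1=N\C(=O)Nc1cccc(Cl)c1`, 15 mg/kg
compound 2, `CN1CCC/C1=N\C(=O)Nc1cccc(C(F)(F)F)c1`, > 25 mg/kg
compound 3, `CCc1cccc(C)c1NC(=O)/N=C1\CCCN1C`, "not determined" (no result reported)

In a functional assay on the whole organism with Rattus norvegicus as the target, with a stated time of 5 days (on this read-out higher numbers stand for an effect only at larger amounts of compound and lower numbers for an effect already at smaller amounts), compound 1 gives 15 mg/kg. For compound 2 only a limit is known, > 25 mg/kg, which is the limit of > 25 mg/kg in this assay, at which 1 of the 3 values shown sits. For compound 3 the result is "not determined" (no result reported). Compound 2 thus stands at the edge of the numbers shown: of three entries, one is a number, one is a limit, and one is absent. The change from compound 2 to compound 4, `CN1CCC/C1=N\C(=O)Nc1cccc(F)c1`, is fluoro in place of trifluoromethyl on an aromatic carbon. Among the measured compounds shown here, the only measured step that bears on it is an at least 1.6-fold higher number from compound 1 to compound 2 (0.22 log units; that floor lies within the scatter), in which chloro gave way to trifluoromethyl on an aromatic carbon and the result moved from a number to a limit. Since compound 1 gives 15 mg/kg with chloro at that carbon, compound 4 with fluoro in its place is expected to land near it. The step of an at least 1.3-fold lower number from compound 2 to compound 4 (0.14 log units; that floor lies within the scatter) is therefore expected to run toward lower numbers, back out of the limit. Compound 4 is estimated at 18 mg/kg, between 8 mg/kg and 40 mg/kg.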

Compound 4, minimum effective dose: 25 mg/kg
Beside the measured number, compound 4's estimate is 1.4-fold (0.14 log units) below it, and the stated range covers the measured number.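

In this assay, fluoro in place of chloro on this aromatic carbon gives a 1.7-fold higher number from compound 1 to compound 4 (0.22 log units; within the scatter), so the measured values do not separate these two groups at this position. Compound 2 has only a limit, not a number: the limit of > 25 mg/kg in this assay, at which 1 of the 4 values shown sits. Fluoro in place of trifluoromethyl on this carbon gives a number no higher from compound 2 to compound 4 (the limit leaves the size open). What compound 4 adds is a second readable number for a single-atom group at this carbon, where trifluoromethyl had yielded none.

The compounds shown leave open how an amine, a carboxylic acid or a methoxy group on this carbon would read in this assay. They also leave open what the ethyl and methyl groups of compound 3 do, as compound 3 has no reported result.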